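The compounds below may be only part of what the source reports. "The series", "measured", "known", "first", "only" and "open" are said of these compounds alone.

Of the compounds shown here, three have been tested in a functional assay on MCF7 cells (Homo sapiens) for antiproliferative activity, read by MTT assay, with a stated time of 72 h; a higher number here means a weaker inhibitor, a lower number a stronger inhibitor. Compound 1 (`CCCCCCCNC[C@@H]1OC[C@H](N)[C@@H]1O`) gives no number, only a limit of the assay, > 128000 nM. Compound 2 (`CCCCCCCCCNC[C@@H]1OC[C@H](N)[C@H]1O`) gives 60300 nM. Compound 3 (`CCCCCCCCCCCCCCNC[C@@H]1OC[C@H](N)[C@H]1O`) gives 8830 nM, the lower of the two actual numbers.

Compound 4 (`CCCCCCCNC[C@@H]1OC[C@H](N)[C@H]1O`) follows from compound 3 by one change, hydrogen in place of heptyl on a saturated chain carbon, seven bonds along the chain from an amine nitrogen.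

For the measured compounds named here, one measured step bears directly on this change. It is a 6.8-fold lower number from compound 2 to compound 3 (0.83 log units; beyond the scatter), where pentyl replaces hydrogen on a saturated chain carbon, nine bonds along the chain from an amine nitrogen. The step to compound 4 removes heptyl rather than adding pentyl, so it runs the opposite way and removes a longer piece of chain. Going by the values given here, on the strength of that single step, a rise somewhat larger than the one seen from compound 2 to compound 3 is expected in this assay. The expected change is a 12-fold higher number from compound 3 to compound 4 (1.10 log units; beyond the scatter). Compound 4 may also be reported only as a limit rather than a number. The estimate for compound 4 is 110000 nM, with an expected range from 55000 nM to 220000 nM.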

Compound 4, half-maximal inhibitory concentration: > 128000 nM
Compound 4: a limit, no number; the forecaster's own chance of this, stated with the estimate: 50%; middle value at least 1.1-fold (0.06 log units) from the limit.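

Compound 4 gives only a limit in this assay, so its steps are minimum sizes: the loss of heptyl gives an at least 14-fold higher number from compound 3 to compound 4 (1.16 log units; beyond the scatter), and the loss of ethyl gives an at least 2.1-fold higher number from compound 2 to compound 4 (0.32 log units; beyond the scatter). Together with the earlier step, this extends the picture from one comparison to three compounds of the same drawn configuration: the number falls as the chain on the amine nitrogen lengthens from compound 4 through compound 2 to compound 3, and shortening the chain at this position does not leave the number unchanged. The step between compound 1 and compound 4 cannot be read, so the result says nothing about the size of any effect of configuration at this chain length, where the two compounds can be compared directly: the fact that compounds 1 and 4 differ only in the configuration as drawn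

Going by these compounds, how far compound 4 and compound 1 actually lie from each other, and from compound 2, stays open: the limit of > 128000 nM in this assay, at which 2 of the 4 values shown sit. Also open is whether a longer chain than that of compound 3, or a carboxylic acid or a second amine on the chain, would carry the fall in the number further or reverse it.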